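This account rests on a few compounds, and the source may have more. Where it says the series, first, only, none or still open, it means among the compounds named here.

In a functional assay on PC-3 cells (Homo sapiens) for cytotoxicity, read by MTT assay, with a stated time of 72 h (on this read-out lower numbers stand for stronger inhibition and higher numbers for weaker inhibition), compound 3 `CCCC(Nc1cncc(-c2ccc(O)c(OC)c2)n1)c1cccc(OC)c1` gives 10000 nM, and compound 1 `CCCC(Nc1cncc(-c2ccc(O)c(OC)c2)n1)c1ccc(Cl)cc1` gives 20000 nM; the gap between them is a 2.0-fold lower number from compound 1 to compound 3 (0.30 log units; within the scatter), which lies within the scatter, so compound 3 stands level with compound 1 among the numbers in hand. For compound 2 `CCCC(Nc1cncc(-c2ccc(O)c(OC)c2)n1)c1ccc(F)cc1` the result in this assay is "not determined" (no result reported). Compound 4 `CCCC(Nc1cncc(-c2ccc(O)c(OC)c2)n1)c1cccc(F)c1` differs from compound 3 by fluoro in place of methoxy on an aromatic carbon. For the measured compounds named here, no measured step swaps a methoxy for a fluoro; the only step available, exchanging one ring substituent for another, stayed within the scatter, so no shift beyond the scatter is expected in either direction in this assay. Compound 4 is therefore estimated at 10000 nM, with a range from 4000 nM to 25000 nM. The expected step is no change at the digits printed from compound 3 to compound 4 (within the scatter).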

Compound 4, half-maximal inhibitory concentration: 600 nM
Estimate against measurement, compound 4: 17-fold (1.22 log units) above, outside the stated range (below it).
By their numbers in this assay, from the lowest: compound 4; then compounds 3 and 1 (each within the scatter of the next).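

In this assay the substituent on this aromatic carbon turns out to matter: fluoro in place of methoxy gives a 17-fold lower number from compound 3 to compound 4 (1.22 log units; beyond the scatter), a shift that the earlier ring change did not show. The change from 4-chlorophenyl to 3-fluorophenyl likewise gives a 33-fold lower number from compound 1 to compound 4 (1.52 log units; beyond the scatter). Nothing available explains why fluoro has this effect.

Compound 2 has no result, so the compounds with a number do not show whether fluoro would do the same elsewhere on the ring. As far as these compounds go, whether a nitrile or an amine on this carbon would match fluoro also remains open.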